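Nitro to Fluoro on Two Hydrazone Thiazole Cores

The source may hold more compounds than are shown below. What is called first, only, known or untested is meant among the compounds shown, and "the series" means these compounds.

The series was examined in an in vitro assay on BTI-TN-5B1-4 cells for inhibition of Amine oxidase [flavin-containing] A (Homo sapiens), read by Amplex Red, with a stated time of 15 min, tested at 100 uM; a higher number here means more inhibition at the concentration tested (going by the name of the read-out), a lower number less inhibition. Compound 1 `O=[N+]([O-])c1ccc(-c2csc(N/N=C\c3ccco3)n2)cc1` gives 40%, and compound 3 `Fc1ccc(-c2csc(N/N=C\c3ccco3)n2)cc1`, which differs from it by the change (fluoro in place of nitro on an aromatic carbon), gives 40%; the step is no change at the digits printed from compound 1 to compound 3 (within the scatter). Compound 2 `O=[N+]([O-])c1ccc(-c2csc(N/N=C\c3cccc4ccccc34)n2)cc1` is reported in this assay as "not active" (no number reported), without a number. How the core of compound 2 differs from the core of compound 1 is not broken down here.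

Compound 4 `Fc1ccc(-c2csc(N/N=C\c3cccc4ccccc34)n2)cc1` has not been measured. Among the measured compounds shown here, it differs from compound 2 by fluoro in place of nitro on an aromatic carbon, the same change as the one between compound 1 and compound 3, since the place of the change reads the same in both cases. In this assay, for the measured compounds named here, the step from compound 2 to compound 4 is expected to be as small as the one from compound 1 to compound 3, because no change at the digits printed from compound 1 to compound 3 (within the scatter). Compound 4 is therefore estimated at 10% in this assay, with an expected range from 0% to 35%, resting on compound 2 being reported as "not active" (no number reported) and on the change leaving compound 1 unmoved.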

Compound 4, a percentage reported as inhibition, at one concentration (the size of the read-out at that concentration, not a potency): 40%
The estimate for compound 4 lay 30 percentage points below the measured number; the measured number lies above the stated range.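

In this assay, among the compounds shown here, compound 4 gives 40% while compound 2 is reported without a number, so no step between compound 2 and compound 4 can be read. The compounds shown leave open how far the change from 4-nitrophenyl to 4-fluorophenyl moves the value on the core of compound 2. Nothing shown here offers an explanation for the result.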